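This account rests on a few compounds, and the source may have more. Where it says the series, first, only, none or still open, it means among the compounds named here.

Measured compounds:
- compound 1, `COc1cc(-c2cc(/C=C/C(=O)c3ccc(N)cc3)[nH]n2)cc(OC)c1OC`: 98%
- compound 2, `COc1ccc(C(=O)/C=C/c2cc(-c3cc(OC)c(OC)c(OC)c3)n[nH]2)cc1OC`: 92%

In a functional assay on OVCAR-8 cells (Homo sapiens) for cytotoxicity, read by sulforhodamine B assay, with a stated time of 48 h, tested at 0.1 uM (on this read-out lower numbers stand for a stronger effect and higher numbers for a weaker effect at the one concentration tested), compound 2 gives the lowest of the two numbers, and the nearest is compound 1, whose value sits higher by a margin inside the scatter, as the step of a number 6 percentage points lower from compound 1 to compound 2 (within the scatter) shows. Compound 3, `COc1cc(C(=O)/C=C/c2cc(-c3cc(OC)c(OC)c(OC)c3)n[nH]2)cc(OC)c1OC`, differs from compound 2 by methoxy in place of hydrogen on an aromatic carbon. Among the measured compounds shown here, no measured step touches that place, and the only step known, on the carbonyl side, stayed within the scatter, so nothing supports a change beyond the scatter. For compound 3 the step I expect is a number 1 percentage points higher from compound 2 to compound 3 (within the scatter). For compound 3 the expected value in this assay is therefore 93%, ranging from 82% to 102%.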

Compound 3, a percentage reported as activity, at one concentration (the size of the read-out at that concentration, not a potency): 94%
Beside the measured number, compound 3's estimate is 1 percentage points below it, and the stated range covers the measured number.
By their numbers in this assay, from the lowest: compounds 2, 3 and 1 (each within the scatter of the next).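

In this assay, among the compounds shown here, the first step at this place, methoxy in place of hydrogen on an aromatic carbon, ortho to a methoxy group and meta to a large group, gives a number 2 percentage points higher from compound 2 to compound 3 (within the scatter). At this one concentration, then, a methoxy group at this position does not move the number beyond the scatter. No other data on these compounds bear on this result. The compounds shown leave open whether a hydroxyl, an amine or a fluorine atom at this position would move the number beyond the scatter. They also leave open whether the methoxy group would make a difference at a higher concentration.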